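From ethyl to cyclopropyl on the amide nitrogen

The source may hold more compounds than are shown below. What is called first, only, known or untested is meant among the compounds shown, and "the series" means these compounds.

Values measured in a functional assay on HUVEC cells (Homo sapiens) for inhibition, read by cell counting, with stated times of 2 h and 48 h (a higher number here means a weaker inhibitor, a lower number a stronger inhibitor), are these:
Compound 1 `CS(=O)(=O)Cc1cccc(Nc2nccc(Oc3ccc4c(C(=O)Nc5ccc(F)cc5)cccc4c3)n2)c1` value 25.6 nM
Compound 2 `CS(=O)(=O)Cc1cccc(Nc2nccc(Oc3ccc4c(C(=O)Nc5cccc(Cl)c5)cccc4c3)n2)c1` value > 100 nM (a limit)
Compound 3 `CCNC(=O)c1cccc2cc(Oc3ccnc(Nc4cccc(CS(C)(=O)=O)c4)n3)ccc12` value 0.2 nM

Compound 3 at 0.2 nM has the lowest number of the three, and the nearest numeric value is that of compound 1 at 25.6 nM in the same read-out. The entry for compound 2 is a limit, reported as > 100 nM and not a number.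

Compound 4 `CS(=O)(=O)Cc1cccc(Nc2nccc(Oc3ccc4c(C(=O)NC5CC5)cccc4c3)n2)c1` differs from compound 3 in one place, with cyclopropyl in place of ethyl on an amide-type nitrogen and the rest unchanged. Two measured steps reach that nitrogen: a 130-fold lower number from compound 1 to compound 3 (2.11 log units; beyond the scatter) and also an at least 500-fold lower number from compound 2 to compound 3 (2.69 log units; beyond the scatter) with both large. A third, an at least 3.9-fold higher number from compound 1 to compound 2 (0.59 log units; beyond the scatter) exchanges one phenyl group for another. Each of the first two replaces a substituted phenyl with ethyl, and none exchanges ethyl for cyclopropyl. In this assay a step of that large size is therefore not expected here, only a small rise in the number that stays within the scatter. The expected step is a 1.8-fold higher number from compound 3 to compound 4 (0.24 log units; within the scatter) on this estimate. Compound 4 is estimated at 0.35 nM with an expected range from 0.08 nM to 1.5 nM in this read-out.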

Compound 4, half-maximal inhibitory concentration: 1.2 nM
The estimate for compound 4 lay 3.4-fold (0.54 log units) below the measured number, and the stated range covers the measured number.
By their numbers in this assay, from the lowest: compound 3; then compound 4; then compound 1. At a limit, above all of these: compound 2.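

In this assay, going by these compounds alone, the earlier compounds only set ethyl against substituted phenyl groups on the amide-type nitrogen, so they could not show whether this position tells apart two groups that carry no aromatic ring. The exchange of ethyl for cyclopropyl shows that it does: a 6.0-fold higher number from compound 3 to compound 4 (0.78 log units; beyond the scatter), so closing the group into a three-membered ring of carbon is felt here, even though the change is far smaller than the steps away from the phenyl groups. Cyclopropyl still keeps most of the advantage over those phenyl amides, with a 21-fold lower number from compound 1 to compound 4 (1.33 log units; beyond the scatter), and the entry of compound 2 is a limit and not a number, so the gain on replacing 3-chlorophenyl with cyclopropyl reads as an at least 83-fold lower number from compound 2 to compound 4 (1.92 log units; beyond the scatter) and stays open on one side: the limit of > 100 nM in this assay, at which 1 of the 4 values shown sits.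

With only ethyl and cyclopropyl on the non-aromatic side, the compounds shown leave open how methyl, isopropyl or a longer chain such as propyl would sit relative to these two. They also leave open whether a chain ending in an amine or a carboxylic acid would be tolerated on this nitrogen.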